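The compounds below may be only part of what the source reports. "The series", "measured", "known", "first", "only" and "open" are said of these compounds alone.

In an ADME assay on HEp-2 cells (Homo sapiens) for cytotoxicity (a lower number here means that less compound is tolerated, a higher number that more compound is tolerated), compound 3 `Cc1cccc(C)c1NC(=O)[C@@H]1CCCN1S(=O)(=O)c1cccc2cccnc12` gives > 50000 nM, which is a limit of the assay and not a number. Its two relatives have real numbers: compound 1 `O=C(Nc1ccccc1)[C@@H]1CCCN1S(=O)(=O)c1cccc2cccnc12` gives 35600 nM, and compound 2 `CC(C)c1ccccc1NC(=O)[C@@H]1CCCN1S(=O)(=O)c1cccc2cccnc12` gives 29900 nM. The next compound, compound 4 `COc1ccc(C)cc1NC(=O)[C@@H]1CCCN1S(=O)(=O)c1cccc2cccnc12`, carries 2-methoxy-5-methylphenyl in place of 2,6-dimethylphenyl on an amide-type nitrogen, a change counted as 2-methoxy-5-methylphenyl in place of 2,6-dimethylphenyl on an amide-type nitrogen.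

Within the data shown here, no measured compound carries the methoxy group, so the closest guide is what happened when the group on that same nitrogen changed. Those steps are an at least 1.4-fold higher number from compound 1 to compound 3 (0.14 log units; that floor lies within the scatter) and an at least 1.6-fold higher number from compound 2 to compound 3 (0.22 log units; that floor lies within the scatter). Both are floors rather than true sizes, and neither clears the scatter. The remaining step, a 1.2-fold lower number from compound 1 to compound 2 (0.08 log units; within the scatter), is also small. Across these three compounds, then, changing this group has not yet shifted this assay measurably.

A modest drop from the limit towards the values of compound 1 and compound 2 therefore seems the likeliest result, though a step within the scatter would be no surprise. The expected step is an at least 1.3-fold lower number from compound 3 to compound 4 (0.14 log units; that floor lies within the scatter). Compound 4 is estimated at 36000 nM, with an expected range of 18000 nM to 50000 nM.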

Compound 4, half-maximal cytotoxic concentration: > 50000 nM
Compound 4: a limit, no number; the forecaster's own chance of this, stated with the estimate: 35%; middle value at least 1.3-fold (0.14 log units) from the limit.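

In this assay, 2-methoxy-5-methylphenyl on the amide-type nitrogen also ends at the limit of the assay, so 2,6-dimethylphenyl is no longer the only group shown there to do so, although 2-isopropylphenyl in compound 2 still gives a real number. Two steps can be read, only as floors, and neither clears the scatter (an at least 1.6-fold higher number from compound 2 to compound 4 (0.22 log units; that floor lies within the scatter)) (an at least 1.4-fold higher number from compound 1 to compound 4 (0.14 log units; that floor lies within the scatter)), so the new group is not shown to differ from 2-isopropylphenyl or phenyl in this assay. The other step, between compound 3 and compound 4, cannot be read, because both compounds carry a limit rather than a number: the limit of > 50000 nM in this assay, at which 2 of the 4 values shown sit.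

From the compounds shown here alone, the true values of compound 3 and compound 4 remain unknown, and so does any real difference between their two groups. Also open, going by these compounds, is whether a carboxylic acid or an amine on this aromatic ring, or a longer chain on the amide-type nitrogen in its place, would give a number clearly apart from those of compound 1 and compound 2.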